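The source may report more compounds than this note shows. Statements on the series, on what has been measured and on what is new or still open speak of the compounds shown alone.

Of the compounds shown here, three have been measured in an assay on CHO cells for displacement of a labelled ligand from melanin-concentrating hormone receptor 1 (Rattus norvegicus), read by scintillation counting, with a stated time of 1 h; on this read-out higher numbers stand for weaker inhibition and lower numbers for stronger inhibition. Compound 1 `Cc1nc2ccc(NC(=O)COc3ccc(OC(F)(F)F)cc3)cn2c1C` gives 7.8 nM. Compound 2 `Cc1oc2ccc(NC(=O)COc3ccc(OC(F)(F)F)cc3)cc2c1C` gives > 1000 nM, which is a limit of the assay rather than a number. Compound 3 `Cc1c(C2CC2)nc2ccc(-n3ccc(OCc4ccc(F)cc4)cc3=O)cn12` gives 28 nM, the higher of the two numbers shown, and its nearest neighbour, compound 1, sits lower by a gap that goes beyond the usual scatter of repeated measurements.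

Compound 4 `Cc1c(C2CC2)nc2ccc(-n3ccc(OCc4ccc(C(F)(F)F)cc4)cc3=O)cn12` has not yet been measured. It differs from compound 3 in a single place: trifluoromethyl in place of fluoro on an aromatic carbon. For the measured compounds named here, no pair of measured compounds differs by exactly this change, so nothing measured shows its size or direction. Both groups sit at the far end of the molecule from the shared core, and the expected step from compound 3 to compound 4 is a 1.4-fold lower number from compound 3 to compound 4 (0.15 log units; within the scatter), a shift that stays within the scatter rather than a clear gain or loss. Compound 4 is therefore estimated at 20 nM, with a likely range from 6 nM to 70 nM.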

Compound 4, half-maximal inhibitory concentration: 82 nM
Estimate against measurement, compound 4: 4.1-fold (0.61 log units) below, outside the stated range (above it).
By their numbers in this assay, from the lowest: compound 1; then compound 3; then compound 4. At a limit, above all of these: compound 2.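

The change from 4-fluorophenyl to 4-(trifluoromethyl)phenyl gives a 2.9-fold higher number from compound 3 to compound 4 (0.47 log units; beyond the scatter) in this assay and shows that this carbon of the aromatic ring is not indifferent to what it carries: the step lies beyond the usual scatter of repeated measurements. The step is modest, and trifluoromethyl, with 4 heavy atoms in place of the 1 of fluoro, goes with the weaker inhibition in this single pair, which sets no general rule. Nothing measured here accounts for the direction of this step.

Still open, on these data alone, is how other groups on the same carbon would compare, such as chloro, methoxy, a nitrile or an amine, or plain hydrogen. As far as these compounds go, it is also open whether the same exchange would shift the number in the same direction on a different core.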